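The source may report more compounds than this note shows. Statements on the series, on what has been measured and on what is new or still open speak of the compounds shown alone.

In a functional assay on EKVX cells (Homo sapiens) for inhibition, read by sulforhodamine B assay, with a stated time of 48 h (on this read-out lower numbers stand for stronger inhibition of growth and higher numbers for weaker inhibition of growth), compound 1 `Cc1ccc(NC(=O)/C=C/c2ccccc2)c(C(N)=O)c1` gives 5180 nM and compound 2 `NC(=O)c1cc(Br)ccc1NC(=O)/C=C/c1ccccc1` gives 2410 nM, the lower of the two numbers. Compound 3 `NC(=O)c1cc(I)ccc1NC(=O)/C=C/c1ccccc1` differs from compound 2 by iodo in place of bromo on an aromatic carbon, with iodo in place of bromo on an aromatic carbon. Within the data shown here, only one measured step bears on this: a 2.1-fold lower number from compound 1 to compound 2 (0.33 log units; beyond the scatter), a modest one, with bromo in place of methyl on an aromatic carbon. A small further lowering in this assay is therefore expected, possibly none beyond the scatter. The estimated change is a 1.2-fold lower number from compound 2 to compound 3 (0.08 log units; within the scatter). For compound 3 the expected value is 2000 nM, within an estimated range of 1000 nM to 4000 nM.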

Compound 3, concentration for 50% growth inhibition: 734 nM
Compound 3: the middle estimate sits 2.7-fold (0.44 log units) above what was measured; measured number outside the range, below it.
By their numbers in this assay, from the lowest: compound 3; then compound 2; then compound 1.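

In this assay, the position para to a large group still responds when one halogen replaces another: iodo in place of bromo gives a 3.3-fold lower number from compound 2 to compound 3 (0.52 log units; beyond the scatter) and is not a silent exchange. Iodo in place of methyl gives a 7.1-fold lower number from compound 1 to compound 3 (0.85 log units; beyond the scatter) at the same place, so compound 3 has the lowest number of the three, with both of its steps beyond the scatter. Nothing measured here explains this change.

The compounds shown leave open whether chloro or fluoro would continue the order from bromo to iodo. They also leave open how an amine or a carboxylic acid would behave at this position.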